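This account rests on a few compounds, and the source may have more. Where it says the series, first, only, none or still open, it means among the compounds named here.

Working notes on the series in a functional assay on A549 cells (Homo sapiens) for cytotoxicity, read by MTT assay, with a stated time of 48 h; on this read-out lower numbers stand for stronger inhibition and higher numbers for weaker inhibition.

Going by the values given here, compound 1 `CCN(CC)c1ccc2cc(C(=O)c3ccc(N4CCN(C(=O)COc5ccc(Cl)cc5Cl)CC4)cc3)oc2c1` gives 5730 nM in this assay and stands lowest of the two numbers measured so far. Compound 2 `CCN(CC)c1ccc2cc(C(=O)c3ccc(N4CCN(C(C)=O)CC4)cc3)oc2c1` gives 30100 nM. Among the compounds with values here, the only step measured between compounds that differ in one place is a 5.3-fold higher number from compound 1 to compound 2 (0.72 log units; beyond the scatter), where hydrogen replaces the 2,4-dichlorophenoxy group on a saturated chain carbon bound to a carbonyl carbon; removing the aromatic ring from that position costs a modest amount of activity.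

Compound 3 `CCN(CC)c1ccc2cc(C(=O)c3ccc(N4CCN(S(=O)(=O)c5ccc(C)cc5)CC4)cc3)oc2c1` is not yet measured. It differs from compound 1 in one place: (4-methylphenyl)sulfonyl in place of ((2,4-dichlorophenoxy)methyl)carbonyl on an amine nitrogen in a ring. The group that enters keeps one six-membered aromatic ring and two hydrogen-bond acceptors on the ring nitrogen, so the change is not the bare truncation seen in compound 2, but the carbonyl and the methylene are gone and the ring is attached through a sulfonyl instead. Within the data shown here, the step from compound 1 to compound 2 is the only measured guide, and it bears on compound 3 only in part, since compound 3 retains an aromatic group where compound 2 has none. A step smaller than that from compound 1 to compound 2 is therefore expected, in the direction of a higher number, and a 1.6-fold higher number from compound 1 to compound 3 (0.20 log units; within the scatter) is the estimate. Compound 3 is expected to give about 9000 nM, with a range from 3000 nM to 27000 nM.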

Compound 3, half-maximal inhibitory concentration: > 40000 nM
Compound 3: no number, only a limit (the forecaster's own chance of this, stated with the estimate: 5%); at least 4.4-fold (0.64 log units) between middle value and limit.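

In this assay compound 3 is recorded only as a limit of the assay, not as a number: the limit of > 40000 nM in this assay, at which 1 of the 3 values shown sits.

On the amine nitrogen in the ring, replacing ((2,4-dichlorophenoxy)methyl)carbonyl with (4-methylphenyl)sulfonyl gives an at least 6.9-fold higher number from compound 1 to compound 3 (0.84 log units; beyond the scatter), so the presence of one six-membered aromatic ring on this nitrogen does not by itself preserve the lower number of compound 1, a point the truncation to acetyl could not show. Replacing acetyl with (4-methylphenyl)sulfonyl gives an at least 1.3-fold higher number from compound 2 to compound 3 (0.12 log units; that floor lies within the scatter), so the sulfonyl-linked aromatic group shows no measurable gain over the acetyl group, and no firm order can be stated for this pair.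

The compounds shown leave open whether the lower number of compound 1 depends on the carbonyl link, the oxygen-and-methylene chain or the two chlorine atoms, since the groups compared differ in all of these at once. A phenoxyacetyl group without chlorine and a 4-methylbenzoyl group on the same ring nitrogen would separate these features.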